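Returning to the Hydantoin Through a Saturated Link

The source may report more compounds than this note shows. Statements on the series, on what has been measured and on what is new or still open speak of the compounds shown alone.

Of the compounds shown here, two sharing one core have been measured so far. Compound 1 `CC(C)C(/C=C1\NC(=O)NC1=O)c1ccc(-c2ccc3cccc(F)c3c2)[nH]c1=O` gives 43 nM in an assay on membranes from Chem-1 cells for displacement of a labelled ligand from prostaglandin E2 receptor EP3 subtype (Homo sapiens), read by scintillation counting, with a stated time of 2 h; a higher number here means a weaker inhibitor, a lower number a stronger inhibitor. Compound 2 `C/C(=C1/OC(=O)NC1=O)C(c1ccc(-c2ccc3cccc(F)c3c2)[nH]c1=O)C(C)C` gives 17 nM in this assay. Going by the values given here, of these two numbers compound 2 stands lowest, and the single step between them, a 2.5-fold lower number from compound 1 to compound 2 (0.40 log units; beyond the scatter), is a modest gain. Compound 3 `CC(C)C(CC1NC(=O)NC1=O)c1ccc(-c2ccc3cccc(F)c3c2)[nH]c1=O` has not yet been measured. It differs from compound 2 in one place: a group of 8 heavy atoms (4 carbon, 2 nitrogen, 2 oxygen; one five-membered non-aromatic ring with 2 hetero atoms) in place of a group of 9 heavy atoms (5 carbon, 1 nitrogen, 3 oxygen; one five-membered non-aromatic ring with 2 hetero atoms), on a saturated chain carbon bound to an aromatic carbon and a saturated chain carbon. This change brings back the ring of compound 1, now attached as a (2,5-dioxoimidazolidin-4-yl)methyl group rather than through a double bond. Among the compounds with values here, only the step from compound 1 to compound 2 bears on this, and it runs backwards here, so a modest loss is expected, of about a 4.1-fold higher number from compound 2 to compound 3 (0.61 log units; beyond the scatter). Within the data shown here, the saturated attachment has no measured counterpart, which widens the range. Compound 3 is therefore estimated at 70 nM, between 25 nM and 250 nM.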

Compound 3, inhibition constant: 10 nM
Compound 3: middle estimate off by 7.0-fold (0.85 log units), on the high side; measured number below the stated range.
By their numbers in this assay, from the lowest: compounds 3 and 2 (each within the scatter of the next); then compound 1.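

In this assay, the (2,5-dioxoimidazolidin-4-yl)methyl group and the group it replaces cannot be told apart at this position, with a 1.7-fold lower number from compound 2 to compound 3 (0.23 log units; within the scatter). The more telling comparison keeps the same ring and changes how it is attached: going to the saturated link gives a 4.3-fold lower number from compound 1 to compound 3 (0.63 log units; beyond the scatter), the first sign that the link matters here as well as the ring. No available measurement explains either result.

As far as these compounds go, whether a carboxylic acid could stand in place of the ring on this saturated chain carbon remains open. So does whether a longer chain carrying the same ring would give a similar number in this assay.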